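Acetyl in place of nitro on compound 1

This account rests on a few compounds, and the source may have more. Where it says the series, first, only, none or still open, it means among the compounds named here.

Working notes on the series. In a functional assay on DU-145 cells (Homo sapiens) for antiproliferative activity, read by MTT assay, with a stated time of 72 h (a higher number here means a weaker inhibitor, a lower number a stronger inhibitor), compound 1 `O=C1OCC[C@@H]1NC(=S)SCCOc1ccc([N+](=O)[O-])cc1` gives 31000 nM. Compound 3 `O=C(COc1ccc(C(=O)/C=C/c2cccc([N+](=O)[O-])c2)cc1)N[C@H]1CCOC1=O` gives 41800 nM, which lies within the scatter of compound 1. Only these two compounds have numbers. Compound 2 `CCCCCCCCCCSC(=S)N[C@H]1CCOC1=O` gives > 64000 nM, which is a limit of the assay and not a number.

The next compound to read is compound 4 `CC(=O)c1ccc(OCCSC(=S)N[C@H]2CCOC2=O)cc1`, which has acetyl in place of nitro on an aromatic carbon, para to a large group (acetyl in place of nitro on an aromatic carbon). Going by the values given here, no measured pair isolates a change at this carbon, so this assay offers no direct guide to its size. No shift beyond the scatter is expected in either direction, and the expectation rests on compound 1 at 31000 nM. The expected change is a 1.2-fold higher number from compound 1 to compound 4 (0.09 log units; within the scatter), which stays within the scatter. A limit reading also remains possible. Compound 4 is estimated at 38000 nM, with an expected range of 17000 nM to 64000 nM.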

Compound 4, half-maximal inhibitory concentration: 32600 nM
Compound 4: the middle estimate sits 1.2-fold (0.07 log units) above what was measured; low and high end bracket the measured number.
By their numbers in this assay, from the lowest: compounds 1, 4 and 3 (each within the scatter of the next). At a limit, above all of these: compound 2.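

In this assay, going by these compounds alone, acetyl in place of nitro on an aromatic carbon, para to a large group, gives a 1.1-fold higher number from compound 1 to compound 4 (0.02 log units; within the scatter), and this is the first pair to isolate this carbon. The assay does not separate the two groups, so nitro is not needed at this position for a value of this size, and the exchange alone leaves the read-out within the scatter. Nothing at hand explains why these two groups read alike.

From the compounds shown here alone, whether any group at this carbon can move the value beyond the scatter remains open, since nitro and acetyl are the only two compared here. An amine, a carboxylic acid or a longer chain in the same place would test this in this assay.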